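Trimming a methoxy group from compound 2

The source may hold more compounds than are shown below. What is called first, only, known or untested is meant among the compounds shown, and "the series" means these compounds.

Compound 2 `COc1cc(-c2cc(/C=C/C(=O)c3ccc(N)cc3)[nH]n2)cc(OC)c1OC` was tested in a functional assay on OVCAR-5 cells (Homo sapiens) for cytotoxicity, read by sulforhodamine B assay, with a stated time of 48 h, tested at 100 uM (on this read-out lower numbers stand for a stronger effect and higher numbers for a weaker effect at the one concentration tested), where compound 2 gives -66%, the second highest of the three numbers. Its nearest neighbour is compound 3 `COc1ccc(C(=O)/C=C/c2cc(-c3cc(OC)c(OC)c(OC)c3)n[nH]2)cc1`, which gives -59%; the move a number 7 percentage points higher from compound 2 to compound 3 (within the scatter) swaps a methoxy for an amino group. The furthest is compound 1 `COc1ccc(-c2cc(/C=C/C(=O)c3ccc(N)cc3)[nH]n2)cc1`, which gives -86%. Compound 4 `COc1ccc(-c2cc(/C=C/C(=O)c3ccc(N)cc3)[nH]n2)cc1OC` differs from compound 2 by hydrogen in place of methoxy on an aromatic carbon. Among the compounds with values here, no measured step removes a methoxy group, so the only guide is that compound 1, with fewer methoxy groups than compound 2, shows the lower number. Compound 4 is therefore expected to fall between the two, with an estimated step of a number 9 percentage points lower from compound 2 to compound 4 (within the scatter), giving an estimate of -75% within a range from -95% to -55%.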

Compound 4, a percentage reported as activity, at one concentration (the size of the read-out at that concentration, not a potency): -81%
Compound 4: middle estimate off by 6 percentage points, on the high side, and the stated range covers the measured number.
By their numbers in this assay, from the lowest: compounds 1 and 4 (each within the scatter of the next); then compounds 2 and 3 (each within the scatter of the next).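

In this assay, the position ortho to a methoxy group and meta to a large group now has a measured change of its own: hydrogen in place of methoxy gives a number 15 percentage points lower from compound 2 to compound 4 (beyond the scatter). Methoxy in place of hydrogen at the neighbouring ring position on compound 1 gives only a number 5 percentage points higher from compound 1 to compound 4 (within the scatter), so in this series the third methoxy group, not the second, gives a step beyond the scatter. Nothing available explains this step.

Going by these compounds, it remains open how a hydroxyl, an ethoxy group or a fluorine would behave at this position. On these data alone, it is also open whether removing this methoxy group has the same effect when methoxy replaces the amino group, as in compound 3.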